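Hydroxy for hydrogen on the pendant phenyl ring

The source may hold more compounds than are shown below. What is called first, only, known or untested is meant among the compounds shown, and "the series" means these compounds.

Measured compounds:
- compound 1, `Cc1cc(-c2cccc(F)c2)c2ncc(CSCCc3ccccc3)n2c1`, 20 ug/mL
- compound 2, `c1ccc(CCSCc2cnc3ccc(-c4ccccc4)cn23)cc1`, 4 ug/mL
- compound 3, `Cc1cc(-c2ccccc2)cn2c(CSCCc3ccccc3)cnc12`, 20 ug/mL

The three compounds were tested in an ADME assay on HEL cells (Homo sapiens) for cytotoxicity, with a stated time of 3 days; a lower number here means that less compound is tolerated, a higher number that more compound is tolerated. Compound 3 stands level with compound 1 at the digits given, and the two together hold the highest numbers of the three. Among the measured compounds shown here, compound 2 gives the lowest number; the only single-point step on record, a 5.0-fold higher number from compound 2 to compound 3 (0.70 log units; beyond the scatter), is modest but lies beyond the scatter.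

Compound 4, `Cc1cc(-c2ccc(O)cc2)cn2c(CSCCc3ccccc3)cnc12`, has not yet been measured. It differs from compound 3 in one place: hydroxy in place of hydrogen on an aromatic carbon. The change is a hydroxy in place of hydrogen on an aromatic carbon of a six-membered aromatic ring of carbon only; cut one bond further out, it reads phenyl to 4-hydroxyphenyl.

For the measured compounds named here, no measured step bears directly on this change: the one step on record concerns a methyl in place of hydrogen, not a hydroxy. There is therefore nothing in the data to point in either direction, and the expected step, no change at the digits printed from compound 3 to compound 4 (within the scatter), is none beyond the scatter. Compound 4 is estimated at 20 ug/mL, with a range from 8 ug/mL to 50 ug/mL in this assay.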

Compound 4, minimum cytotoxic concentration: >= 100 ug/mL
Compound 4: no number, only a limit (the forecaster's own chance of this, stated with the estimate: 20%); middle value at least 5.0-fold (0.69 log units) from the limit.
By their numbers in this assay, from the lowest: compound 2; then compounds 1 and 3 (each within the scatter of the next). At a limit, above all of these: compound 4.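

In this assay, compound 4 gives no number, only a limit: the limit of >= 100 ug/mL in this assay, at which 1 of the 4 values shown sits. Hydroxy in place of hydrogen on the pendant phenyl ring, para to a large group, thus gives an at least 5.0-fold higher number from compound 3 to compound 4 (0.69 log units; beyond the scatter), and the true size of this step stays unknown. Among the compounds shown here, the only earlier step lay on the core and concerned a methyl, so this result is the first to show that a change on the pendant ring, and a hydroxy in particular, can also move the number beyond the scatter, in the direction of more compound tolerated.

The compounds shown leave open whether this shift belongs to the hydroxy itself or would come with other groups on the same carbon, such as a methoxy, an amine or a carboxylic acid. They also leave open whether the hydroxy would produce a similar shift on the core of compound 2, which lacks the methyl, and how high the number would lie if it could be read past the limit.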